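Swapping the nitro-bearing ring for a methylpyridine

This account rests on a few compounds, and the source may have more. Where it says the series, first, only, none or still open, it means among the compounds named here.

Of the compounds shown here, three sharing one core have been measured. Compound 1 `O=C(Nc1cc(-c2ccccc2)nn1-c1ccccc1)c1cccc(C(F)(F)F)c1` gives 228 nM in a functional assay on cells for positive allosteric modulation of metabotropic glutamate receptor 5 (Rattus norvegicus), read by calcium flux; a lower number here means that less compound is needed, a higher number that more compound is needed for the effect. Compound 2 `O=C(Nc1cc(-c2ccccc2)nn1-c1ccccc1)c1cccc([N+](=O)[O-])c1` gives 39 nM, and compound 3 `O=C(Nc1cc(-c2ccccc2)nn1-c1ccccc1)c1ccc([N+](=O)[O-])cc1` gives 10.7 nM. The steps were a 5.8-fold lower number from compound 1 to compound 2 (0.77 log units; beyond the scatter), a 21-fold lower number from compound 1 to compound 3 (1.33 log units; beyond the scatter) and a 3.6-fold lower number from compound 2 to compound 3 (0.56 log units; beyond the scatter). Compound 3 therefore stands at the lowest number of the three, with both of its steps to the others beyond the scatter, making it the most potent of this small set.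

Compound 4 `Cc1ccc(C(=O)Nc2cc(-c3ccccc3)nn2-c2ccccc2)cn1` is not yet measured. Its change from compound 3 is 6-methylpyridin-3-yl in place of 4-nitrophenyl on a carbonyl carbon. For the measured compounds named here, no measured step swaps the nitro for a pyridine nitrogen, so the direction rests on analogy alone: the measured steps show that the ring on the carbonyl carbon moves the number strongly, and the one change of group on that ring, from trifluoromethyl to nitro, was sizable. Removing the nitro is therefore expected to raise the number, with the step from compound 3 to compound 4 estimated at a 9.3-fold higher number from compound 3 to compound 4 (0.97 log units; beyond the scatter). Compound 4 is expected to give about 100 nM, within a range from 25 nM to 400 nM.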

Compound 4, half-maximal effective concentration: 280 nM
Beside the measured number, compound 4's estimate is 2.8-fold (0.45 log units) below it; low and high end bracket the measured number.
By their numbers in this assay, from the lowest: compound 3; then compound 2; then compounds 1 and 4 (each within the scatter of the next).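

On the carbonyl carbon, 6-methylpyridin-3-yl gives up the low numbers seen with both nitro-bearing rings: this assay shows a 26-fold higher number from compound 3 to compound 4 (1.42 log units; beyond the scatter) and a 7.2-fold higher number from compound 2 to compound 4 (0.86 log units; beyond the scatter). Set against 3-(trifluoromethyl)phenyl, the same ring gives a 1.2-fold higher number from compound 1 to compound 4 (0.09 log units; within the scatter), so these two quite different rings cannot be told apart here, while both nitro-bearing rings stand clearly apart from them. The data at hand offer no explanation for this split.

From the compounds shown here alone, the ring nitrogen and the methyl enter together in compound 4, so the share of each in the change remains open. Also open, going by these compounds, is how a plain pyridin-3-yl ring, or a phenyl ring carrying an amine or a carboxylic acid where the nitro sits in compound 3, would compare with these compounds.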